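Methyl for Trifluoromethyl in a Series That Barely Binds

The source may hold more compounds than are shown below. What is called first, only, known or untested is meant among the compounds shown, and "the series" means these compounds.

Compound 1 `CC(=O)/C(=N\Nc1ccccc1C(F)(F)F)N(C)c1cccc(Cl)c1` and compound 3 `CC(=O)/C(=N\Nc1ccccc1C)N(C)c1cccc(Cl)c1` differ in one place, and compound 2 `CC(=O)/C(=N\Nc1ccccc1C(F)(F)F)Oc1cccc(Cl)c1` and the not yet measured compound 4 `CC(=O)/C(=N\Nc1ccccc1C)Oc1cccc(Cl)c1` differ in that same place. How the core of compound 1 differs from the core of compound 2 is not broken down here.

In an assay on isolated protein for binding affinity to corticotropin-releasing factor receptor 1 (Homo sapiens) (a higher number here means a weaker inhibitor, a lower number a stronger inhibitor), compound 1 gives > 10000 nM, which is a limit of the assay and not a number. Compound 3 gives > 10000 nM in this assay, again a limit. The change between them is methyl in place of trifluoromethyl on an aromatic carbon, and the step it made is a step that the two limits leave unreadable from compound 1 to compound 3. Compound 2 gives > 10000 nM in this assay, once more a limit. All three measured values sit at the limit of > 10000 nM in this assay, at which 3 of the 3 values shown sit.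

Compound 4 arises from compound 2 by the same kind of change, (methyl in place of trifluoromethyl on an aromatic carbon). The expected step from compound 2 to compound 4 is a step that the limit leaves unreadable from compound 2 to compound 4, set beside the unreadable earlier step, and this expectation rests on compound 2 giving > 10000 nM and on compound 3 giving > 10000 nM. Compound 4 is therefore expected to give about 15000 nM in this assay, with a range estimated from 5000 nM to 50000 nM, most likely reported again only as a limit.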

Compound 4, inhibition constant: > 10000 nM
Compound 4: a limit, no number; the forecaster's own chance of this, stated with the estimate: 85%; the middle value lies beyond the limit too.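

Compound 2 and compound 4 each give only a limit of the assay and not a number, so the size of the step from trifluoromethyl to methyl between them cannot be read. The compounds shown leave open how strongly any of them binds in this assay, and whether this change alters binding at all, as all share one limit: the limit of > 10000 nM in this assay, at which 4 of the 4 values shown sit.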